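From Cyclopentyl to Benzyl: Estimating a Half-Life

The source may report more compounds than this note shows. Statements on the series, on what has been measured and on what is new or still open speak of the compounds shown alone.

Half-life data exist for three compounds that share one core. In an in vitro ADME assay on the whole organism (small intestine) for pharmacokinetics, with Rattus norvegicus as the target (a lower number here means that the compound disappears faster, a higher number that the compound lasts longer), compound 1 `C=CCN(CCCC(=O)O)C(=O)/C(C)=C/c1ccc(C(=O)Oc2ccc(C(=N)N)cc2)cc1` gives 0.917 h, and compound 2 `CCOC(=O)CCCN(C(=O)/C(C)=C/c1ccc(C(=O)Oc2ccc(C(=N)N)cc2)cc1)C(C(=O)OCC)C(=O)OCC` gives 1 h. These two values lie within the usual scatter of each other, so they cannot be put in order.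

Compound 3 `CCOC(=O)CN(C(=O)/C(C)=C/c1ccc(C(=O)Oc2ccc(C(=N)N)cc2)cc1)C1CCCC1` has no exact number in this assay: its entry, > 1 h, is a limit. That places compound 3 at the limit of > 1 h in this assay, at which 1 of the 3 values shown sits. Its true half-life is therefore not known.

Compound 4 `CCOC(=O)CN(Cc1ccccc1)C(=O)/C(C)=C/c1ccc(C(=O)Oc2ccc(C(=N)N)cc2)cc1` has not yet been measured. It has benzyl in place of cyclopentyl on an amide-type nitrogen. For the measured compounds named here, no two measured compounds differ in only one place, so no measured step shows what a change like this does. The expectation leans on compound 3 and its limit > 1 h, since this is the measured compound that differs from compound 4 by this single swap.

The estimated change, a step that the limit leaves unreadable from compound 3 to compound 4, is expected to stay within the usual scatter, with no firm direction. The estimated half-life of compound 4 is 1.2 h, with an expected range of 0.6 h to 2.5 h.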

Compound 4, half-life: 0.733 h
Estimate against measurement, compound 4: 1.6-fold (0.21 log units) above, within the range that was stated.
By their numbers in this assay, from the lowest: compounds 4, 1 and 2 (each within the scatter of the next).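

Benzyl in place of cyclopentyl on an amide-type nitrogen is the one change here that can be read at a single place, and in this assay it gives an at least 1.3-fold lower number from compound 3 to compound 4 (0.13 log units; that floor lies within the scatter). The entry for compound 3, > 1 h, is a limit and not a number. The step therefore has only a floor, and that floor cannot say whether the true change is small enough to vanish into ordinary repeat variation or much larger, because the starting point of the step is open: the limit of > 1 h in this assay, at which 1 of the 4 values shown sits.

The swap replaces a five-membered non-aromatic ring with a six-membered aromatic ring and also changes the number of heavy atoms, so this single step cannot tell which of those differences matters, if any does. Going by these compounds, how a plain methyl, a phenylethyl chain or an aminoethyl group would fare on this same nitrogen remains open, and so does an exact half-life for compound 3, which would turn the floor into a true step size.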